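This account rests on a few compounds, and the source may have more. Where it says the series, first, only, none or still open, it means among the compounds named here.

Working notes on the series. Compound 3 `N#CC1=C(NC(=O)c2ccccc2O)N(c2ccccc2)C(=O)N2CCCCC(N3CCCC3)C12` stands highest of the three numbers in a functional assay on the whole organism (strain albino) for inhibition, with Rattus norvegicus as the target, read by paw edema, with a stated time of 1 h, at a dose of 20 mmol/kg by the intraperitoneal route; on this read-out lower numbers stand for less inhibition and higher numbers for more inhibition at the one dose given (going by the name of the read-out); compound 3 gives 44.7%. Compound 1 `N#CC1=C(NCN2CCCC2)N(c2ccccc2)C(=O)N2CCCCC(N3CCCC3)C12` gives 22.9%, and compound 2 `COc1ccc(N/C=N/C2=C(C#N)C3C(N4CCCC4)CCCCN3C(=O)N2c2ccccc2)cc1` gives 20.6%; the difference between these two, a number 2.3 percentage points lower from compound 1 to compound 2 (within the scatter), is within the scatter, so they cannot be ordered. Both rises to compound 3 are beyond the scatter: a number 21.8 percentage points higher from compound 1 to compound 3 (beyond the scatter) and a number 24.1 percentage points higher from compound 2 to compound 3 (beyond the scatter).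

Among the compounds with values here, compound 4 `N#CC1=C(NCC(=O)N2CCCCC2)N(c2ccccc2)C(=O)N2CCCCC(N3CCCC3)C12` has no measurement yet. Its change from compound 3 is ((piperidin-1-yl)carbonyl)methyl in place of (2-hydroxyphenyl)carbonyl on an amine nitrogen. The step that bears on this most directly is a number 21.8 percentage points higher from compound 1 to compound 3 (beyond the scatter), in which the (2-hydroxyphenyl)carbonyl now leaving compound 3 replaced (pyrrolidin-1-yl)methyl on that same amine nitrogen. Within the data shown here, compound 4 again carries a methyl-linked group with a non-aromatic nitrogen ring on that nitrogen, so the move is read as roughly the reverse of that step, and most of the gain seen in compound 3 is expected to be given back; since the entering group is not identical to the one in compound 1, the return is taken as partial rather than complete. The expected step in this assay is therefore a number 16.7 percentage points lower from compound 3 to compound 4 (beyond the scatter), downward and beyond the scatter. Compound 4 is estimated at 28%, with a range from 15% to 42%.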

Compound 4, a percentage reported as inhibition, in the whole organism at one dose (the size of the read-out at that dose, not a potency): 38%
Estimate against measurement, compound 4: 10 percentage points below, and the stated range covers the measured number.
By their numbers in this assay, from the lowest: compounds 2 and 1 (each within the scatter of the next); then compounds 4 and 3 (each within the scatter of the next).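

In this assay, the amine nitrogen carries ((piperidin-1-yl)carbonyl)methyl and (2-hydroxyphenyl)carbonyl with no separable difference, a number 6.7 percentage points lower from compound 3 to compound 4 (within the scatter), so at this position the aromatic ring and the hydrogen-bond donor of the leaving group are not required for a number at this level. A methyl link to a non-aromatic nitrogen ring does not by itself mark the low level, as the change of pyrrolidin-1-yl to (piperidin-1-yl)carbonyl on the saturated chain carbon gives a number 15.1 percentage points higher from compound 1 to compound 4 (beyond the scatter). The replacement of the larger group of compound 2 on the double-bonded ring carbon gives a step of similar size, a number 17.4 percentage points higher from compound 2 to compound 4 (beyond the scatter), so two different substituents on that nitrogen now stand clear of compounds 1 and 2.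

No measured evidence on the series accounts for these steps. The step from compound 1 to compound 4 changes both the ring and the carbonyl, so open questions remain as to which of them carries the rise, and a (pyrrolidin-1-yl)carbonyl or a carboxylic acid on the same methyl link would separate the two.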